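Bromine on the Indoline Ring of a Diterpenoid Core

The source may report more compounds than this note shows. Statements on the series, on what has been measured and on what is new or still open speak of the compounds shown alone.

Measured compounds:
compound 1 `COC(=O)[C@@]1(C)CCC=C2[C@@H]1CC[C@@H](C)[C@]2(C)Cc1c[nH]c2ccc(C)cc12` — 20000 nM
compound 2 `COC(=O)[C@@]1(C)CCC=C2[C@@H]1CC[C@@H](C)[C@]2(C)Cc1c(C)[nH]c2ccc(Br)cc12` — 16000 nM
compound 3 `COC(=O)[C@@]1(C)CC[C@@H]2C3=C1CC[C@@H](C)[C@]3(C)C[C@@H]1c3ccccc3N[C@H]21` — 35000 nM

All three were tested in a functional assay on T47D cells (Homo sapiens) for inhibition, read by sulforhodamine B assay, with a stated time of 48 h; on this read-out lower numbers stand for stronger inhibition of growth and higher numbers for weaker inhibition of growth. Compound 1 gives 20000 nM and compound 2 gives 16000 nM, both weak. Compound 3 gives 35000 nM, the highest of the three numbers; its gap to compound 1 lies within the scatter, so the two cannot be told apart, while its gap to compound 2 lies beyond the scatter. Within the data shown here, no pair of these three differs in one place only, so no clean step can be read from the measured set.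

Compound 4 `COC(=O)[C@@]1(C)CC[C@@H]2C3=C1CC[C@@H](C)[C@]3(C)C[C@@H]1c3cc(Br)ccc3N[C@H]21` is the next compound, not yet measured. It differs from compound 3 by bromo in place of hydrogen on an aromatic carbon. Among the measured compounds shown here, nothing among the measured compounds isolates what a bromo in this place does on the indoline-bearing core, so the expectation rests on compound 3 alone. Because compound 3 gives 35000 nM, compound 4 is expected to stay in the same weak range, with a step from compound 3 to compound 4 of a 1.2-fold lower number from compound 3 to compound 4 (0.07 log units; within the scatter), that is, none beyond the scatter. The estimate for compound 4 is 30000 nM, with a range from 12000 nM to 75000 nM.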

Compound 4, concentration for 50% growth inhibition: 31000 nM
The estimate for compound 4 lay 1.0-fold (0.01 log units) below the measured number; the measured number falls inside the stated range.
By their numbers in this assay, from the lowest: compounds 2, 1, 4 and 3 (each within the scatter of the next, the first and the last beyond it).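

In this assay, bromo in place of hydrogen on this aromatic carbon gives a 1.1-fold lower number from compound 3 to compound 4 (0.05 log units; within the scatter), so compound 3 and compound 4 cannot be told apart. Among these compounds, this is the first step in the set that changes one place only, and it shows that this carbon, meta to a fused ring and para to a fused ring, can carry a bromine atom while growth inhibition stays in the same weak range; the bromo neither clearly helps nor clearly harms on this read-out. No evidence is available on why the number holds steady at this position.

As far as these compounds go, a single substituent at a single carbon says little about the position as a whole, so it remains open whether an amine, a carboxylic acid or a methoxy group here would move the number beyond the usual scatter. From the compounds shown here alone, it is equally open whether bromo on another carbon of the same aromatic ring would leave the number just as unchanged, or whether any change on this ring can lift the core out of its weak range.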